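Cyano to methyl on the anilide ring of compound 2

The source may report more compounds than this note shows. Statements on the series, on what has been measured and on what is new or still open speak of the compounds shown alone.

Compound 1 `COc1cc(CN(C(=O)Nc2ccc(C#N)cc2)n2cnnc2)cc(OC)c1OC` gives 21000 nM in a functional assay on B16-F10 cells (Mus musculus) for cytotoxicity, read by MTT assay, with a stated time of 48 h; on this read-out lower numbers stand for stronger inhibition and higher numbers for weaker inhibition. Compound 2 `COc1ccc(CN(C(=O)Nc2ccc(C#N)cc2)n2cnnc2)cc1OC` returns only a limit of the assay, > 50000 nM, in this assay. The step of an at least 2.3-fold higher number from compound 1 to compound 2 (0.37 log units; beyond the scatter) is thus known only as a bound, fixed by the limit of > 50000 nM in this assay, at which 1 of the 2 values shown sits. Compound 2 therefore stands at the weak end of the two values shown, without a number of its own.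

Compound 3 `COc1ccc(CN(C(=O)Nc2ccc(C)cc2)n2cnnc2)cc1OC` differs from compound 2 by methyl in place of cyano on an aromatic carbon. Within the data shown here, no measured step touches the cyano group; the single measured step, an at least 2.3-fold higher number from compound 1 to compound 2 (0.37 log units; beyond the scatter), concerns a methoxy group on the other ring and does not bear on the present change. With compound 2 already at the limit, the expected step that the limit leaves unreadable from compound 2 to compound 3 in this assay cannot be fixed in either direction from the numbers shown. Compound 3 is accordingly estimated at 70000 nM, in the range 25000 nM to 200000 nM, most likely reported again as a limit.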

Compound 3, half-maximal inhibitory concentration: 29900 nM
For compound 3 the middle estimate is 2.3-fold (0.37 log units) above the measured one; the measured number falls inside the stated range.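

Replacing 4-cyanophenyl with 4-methylphenyl gives a readable number at this position, where the nitrile-bearing partner gave none: in this assay compound 3 gives 29900 nM. Compound 2 remains a limit of the assay, > 50000 nM. The change therefore reads as an at least 1.6-fold lower number from compound 2 to compound 3 (0.22 log units; that floor lies within the scatter), so the data give only a floor for its size and do not establish a change beyond the scatter: the limit of > 50000 nM in this assay, at which 1 of the 3 values shown sits.

Still open, on these data alone, is how an amine, a carboxylic acid or a longer alkyl chain would read at this position on the otherwise unchanged core of compound 3. Also open, as far as these compounds go, is whether the additional methoxy group that separates compound 1 from compound 2 would give a comparable step with methyl in place of cyano.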